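The source may report more compounds than this note shows. Statements on the series, on what has been measured and on what is new or still open speak of the compounds shown alone.

Compound 1 `O=C(NCc1cn(Cc2ccc(C(F)(F)F)cc2)nn1)c1cn(-c2ccccc2)nc1-c1ccc(Cl)cc1` gives 1100 nM in a functional assay on MIA PaCa-2 cells (Homo sapiens) for antiproliferative activity, read by sulforhodamine B assay, with a stated time of 48 h; a lower number here means a stronger inhibitor of growth, a higher number a weaker inhibitor of growth. Compound 2 `COc1ccc(Cn2cc(CNC(=O)c3cn(-c4ccccc4)nc3-c3ccc(Cl)cc3)nn2)cc1` gives 290 nM. Compound 3 `COc1cc(Cn2cc(CNC(=O)c3cn(-c4ccccc4)nc3-c3ccc(Cl)cc3)nn2)cc(OC)c1` gives 340 nM.

Compound 1 stands highest of the three numbers, so it is the weakest growth inhibitor shown, and both steps away from it, a 3.8-fold lower number from compound 1 to compound 2 (0.58 log units; beyond the scatter) and a 3.2-fold lower number from compound 1 to compound 3 (0.51 log units; beyond the scatter), lie beyond the scatter. Compound 4 `COc1ccc(-c2nn(-c3ccccc3)cc2C(=O)NCc2cn(Cc3ccc(C(F)(F)F)cc3)nn2)cc1` differs from compound 1 in one place: methoxy in place of chloro on an aromatic carbon. For the measured compounds named here, no measured step swaps a chloro for a methoxy on this ring; the two steps that brought a methoxy in did so on the other ring, and each was modest. The remaining pair differs only within the scatter, a 1.2-fold higher number from compound 2 to compound 3 (0.07 log units; within the scatter). Going by the values given here, with no direct precedent, the step is expected to be small, a 1.2-fold lower number from compound 1 to compound 4 (0.09 log units; within the scatter). Compound 4 is estimated at 900 nM, between 300 nM and 2700 nM.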

Compound 4, concentration for 50% growth inhibition: > 100000 nM
Compound 4: a limit, no number; the forecaster's own chance of this, stated with the estimate: 5%; at least 110-fold (2.04 log units) between middle value and limit.
By their numbers in this assay, from the lowest: compounds 2 and 3 (each within the scatter of the next); then compound 1. At a limit, above all of these: compound 4.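

Changing 4-chlorophenyl to 4-methoxyphenyl gives the first large step among these compounds, an at least 90-fold higher number from compound 1 to compound 4 (1.95 log units; beyond the scatter), whereas the steps among compounds 1, 2 and 3 were modest or within the scatter. In this assay, compound 4 has a limit and no number: the limit of > 100000 nM in this assay, at which 1 of the 4 values shown sits. Methoxy came with a lower number on the other ring in compound 2, but here it comes with a far higher one, so its effect does not carry over between these two places.

The compounds shown leave open whether this loss belongs to methoxy alone or to any replacement of chloro at this place. A methyl, a fluoro or an amine there could separate the two.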